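Swapping a ring substituent on a benzamide-based antiproliferative

The source may hold more compounds than are shown below. What is called first, only, known or untested is meant among the compounds shown, and "the series" means these compounds.

Measured compounds:
- compound 1, `Nc1ccccc1NC(=O)c1ccc(CSC(=S)N2CCN(c3ccc(F)cc3)CC2)cc1`: 20.9%
- compound 2, `COC(=O)c1ccc2c(c1)CCN2C(=S)SCc1ccc(C(=O)Nc2ccccc2N)cc1`: 37.5%

Of the compounds shown here, two have been tested so far in a functional assay on A-375 cells (Homo sapiens) for antiproliferative activity, read by CCK-8 assay, with a stated time of 72 h, tested at 2 uM; a lower number here means a weaker effect, a higher number a stronger effect of the compound at the concentration tested. Compound 1 gives 20.9% and compound 2 gives 37.5%. Compound 1 therefore stands lowest of the two numbers, and the gap to compound 2 lies beyond the usual scatter. Among the measured compounds shown here, the two share the same core, a benzamide carrying an aminophenyl group, and differ in the part attached to the thiocarbonyl sulfur; no single-point step between them is available, so their two values can only be set side by side.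

The next compound, compound 3 `Nc1ccccc1NC(=O)c1ccc(CSC(=S)N2CCN(Cc3ccccc3)CC2)cc1`, is a one-place change from compound 1: benzyl in place of 4-fluorophenyl on an amine nitrogen in a ring. For the measured compounds named here, nothing measured so far shows how this assay responds to such a change on the amine nitrogen in a ring. The expectation is a step of a number 4.1 percentage points higher from compound 1 to compound 3 (within the scatter) from compound 1 to compound 3 that is small and not clearly beyond the scatter. Compound 3 is therefore estimated at 25%, with a range from 10% to 45%.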

Compound 3, a percentage reported as inhibition, at one concentration (the size of the read-out at that concentration, not a potency): 10.6%
Beside the measured number, compound 3's estimate is 14.4 percentage points above it; low and high end bracket the measured number.
By their numbers in this assay, from the lowest: compound 3; then compound 1; then compound 2.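

In this assay, placing benzyl in place of 4-fluorophenyl on an amine nitrogen in a ring gives a step of a number 10.3 percentage points lower from compound 1 to compound 3 (beyond the scatter) and thus shows that this position is sensitive to the group it carries, which the earlier side-by-side values could not show. The change is a subtle one on paper: both groups have the same count of heavy atoms, each has one six-membered aromatic ring of carbon only, and neither has a hydrogen-bond donor or acceptor, so these counts alone do not settle the read-out at this position. No measurement here explains the drop.

The step also combines two differences, the loss of the fluorine and the arrival of an extra carbon, so it cannot say which one matters; a plain phenyl group or a 4-fluorobenzyl group on the same nitrogen would separate them. On these data alone, whether a longer chain such as phenethyl, or a group of another kind such as a carboxylic acid on the benzyl ring, would move the read-out further in either direction remains open.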